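Trifluoromethoxy for Trifluoromethyl: An Expectation for Compound 4

A few compounds are considered here, and "the series" means these few. Any claim that something is new, unique, unknown or untested is made for them only; others in the source may bear on it.

Measured compounds in a functional assay on DU-145 cells (Homo sapiens) for antiproliferative activity, read by propidium iodide staining, with a stated time of 96 h; on this read-out lower numbers stand for stronger inhibition and higher numbers for weaker inhibition:
Compound 1, `CC(O)(COc1cccc(C(F)(F)F)c1)C(=O)Nc1ccc(S(F)(F)(F)(F)F)cc1`, gives 21900 nM.
Compound 2, `CC(O)(COc1cccc(OC(F)(F)F)c1)C(=O)Nc1ccc(S(F)(F)(F)(F)F)cc1`, gives 18400 nM.
Compound 3, `CC(O)(COc1ccccc1C(F)(F)F)C(=O)Nc1cccc(S(F)(F)(F)(F)F)c1`, gives 52200 nM.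

Compound 2 arises from compound 1 by trifluoromethoxy in place of trifluoromethyl on an aromatic carbon, and the step was a 1.2-fold lower number from compound 1 to compound 2 (0.08 log units; within the scatter). Compound 3 has the same atoms as compound 1 joined differently; the difference between the two cores is not broken down here. Compound 4, `CC(O)(COc1ccccc1OC(F)(F)F)C(=O)Nc1cccc(S(F)(F)(F)(F)F)c1`, arises from compound 3 by trifluoromethoxy in place of trifluoromethyl on an aromatic carbon. For the measured compounds named here, this is the same kind of change as the one from compound 1 to compound 2, but the place differs: meta to a large group in the first pair, ortho to a large group in the second. Compound 4 is expected to show a similarly small step, estimated as a 1.2-fold lower number from compound 3 to compound 4 (0.06 log units; within the scatter), because the earlier step was a 1.2-fold lower number from compound 1 to compound 2 (0.08 log units; within the scatter). The estimate for compound 4 in this assay is 45000 nM, expected to lie between 20000 nM and 100000 nM.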

Compound 4, half-maximal inhibitory concentration: 38100 nM
Compound 4: the middle estimate sits 1.2-fold (0.07 log units) above what was measured; the measured number falls inside the stated range.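

In this assay, trifluoromethoxy in place of trifluoromethyl on the core of compound 3 gave a 1.4-fold lower number from compound 3 to compound 4 (0.14 log units; within the scatter). Set beside the earlier step, the result is the same within error: the same change on two cores in this assay, a 1.2-fold lower number (0.08 log units; within the scatter) from compound 1 to compound 2 and a 1.4-fold lower number (0.14 log units; within the scatter) from compound 3 to compound 4, 1.2-fold (0.06 log units) apart, within the scatter of two such steps. This shows that the change carried over between these two cores without a step beyond the scatter, but two pairs do not establish a rule for other cores or other places on the ring, and they do not explain the result.

The compounds shown leave open what an amine, a carboxylic acid or a nitrile would give in place of either group. They also leave open whether the two groups would remain this close on a third core.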